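This account rests on a few compounds, and the source may have more. Where it says the series, first, only, none or still open, it means among the compounds named here.

Measured so far, in a functional assay, with a stated time of 6 min; on this read-out lower numbers stand for stronger inhibition and higher numbers for weaker inhibition:
compound 1 `S=c1[nH]nc(-c2ccc3c(c2)OCCO3)o1` gives 10600 nM;
compound 2 `Fc1ccccc1NCn1nc(-c2ccc3c(c2)OCCO3)oc1=S` gives 6390 nM;
compound 3 `FC(F)(F)c1cccc(NCn2nc(-c3ccc4c(c3)OCCO4)oc2=S)c1` gives 7620 nM.

Compound 2 gives the lowest of the three numbers, but its gaps to compound 3 and to compound 1 both lie within the scatter, so the three compounds are not separated by this assay. Going by the values given here, no pair here differs in a single place, so no measured step is available to guide the next change.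

Compound 4 `S=c1oc(-c2ccc3c(c2)OCCO3)nn1CNc1ccccc1Br` differs from compound 2 as follows: bromo in place of fluoro on an aromatic carbon. With nothing measured for this kind of exchange in the series, no step beyond the scatter is expected in either direction in this assay, and the estimated step of a 1.2-fold lower number from compound 2 to compound 4 (0.07 log units; within the scatter) reflects that. Compound 4 is expected to give about 5500 nM, with a range from 2500 nM to 12000 nM.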

Compound 4, half-maximal inhibitory concentration: 12700 nM
Estimate against measurement, compound 4: 2.3-fold (0.36 log units) below, and the stated range ends below it.
By their numbers in this assay, from the lowest: compounds 2, 3, 1 and 4 (each within the scatter of the next).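

Bromo in place of fluoro on an aromatic carbon, ortho to a large group, gives the first step in the series that differs in one place. In this assay the step is a 2.0-fold higher number from compound 2 to compound 4 (0.30 log units; within the scatter) and stays within the scatter, so this halogen exchange does not separate the two compounds at this position. No supporting measurement bears on this step.
Open, going by these compounds, is whether a methoxy, an amine or a carboxylic acid on this ring carbon would give a step beyond the scatter. Also open, on these data alone, is whether a longer chain in place of the single carbon joining the amino group to the core would do so.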